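Ring-amine substituent variation in the shared core series

This account rests on a few compounds, and the source may have more. Where it says the series, first, only, none or still open, it means among the compounds named here.

Measured compounds, with their read-out in a functional assay on CHO-K1 cells for antagonist activity at adenosine receptor A2b (Homo sapiens), read by FLIPR and calcium flux; on this read-out higher numbers stand for weaker inhibition and lower numbers for stronger inhibition:
compound 1 `Cc1nc(C(=O)c2ccc(C)s2)c2sccc2n1`, a limit of the assay: > 10000 nM
compound 2 `Cc1ccc(C(=O)c2nc(NCc3ccccc3)nc3ccsc23)s1`: 5580 nM
compound 3 `Cc1ccc(C(=O)c2nc(N(C)Cc3cccnc3)nc3ccsc23)s1`: 4140 nM

Compound 2 holds the highest of the two numbers in this assay; compound 3 is nearest, and the gap between them lies within the scatter, so no order can be read from the pair. Within the data shown here, only one step is computed, an at least 1.7-fold lower number from compound 1 to compound 2 (0.25 log units; that floor lies within the scatter), and its floor lies within the scatter because of the limit of > 10000 nM in this assay, at which 1 of the 3 values shown sits.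

Compound 4 `Cc1ccc(C(=O)c2nc(NC(C)c3ccccn3)nc3ccsc23)s1` differs from compound 2 by 1-(pyridin-2-yl)ethyl in place of benzyl on a nitrogen on an aromatic ring. Among the measured compounds shown here, no measured step covers this exchange. Compound 3, whose group on the same nitrogen also holds a ring nitrogen, sits within the scatter of compound 2, which offers the only hint, and it points to no change of size. Compound 4 is therefore expected to stay close to compound 2, with a step of a 1.2-fold lower number from compound 2 to compound 4 (0.09 log units; within the scatter). The estimate for compound 4 in this assay is 4500 nM, between 1500 nM and 12000 nM.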

Compound 4, half-maximal inhibitory concentration: 19 nM
Compound 4: middle estimate off by 240-fold (2.37 log units), on the high side, and the stated range ends above it.
By their numbers in this assay, from the lowest: compound 4; then compounds 3 and 2 (each within the scatter of the next). At a limit, above all of these: compound 1.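

In this assay, among these compounds, the group on the nitrogen on an aromatic ring can move the read-out strongly, which the earlier compounds did not show: the exchange of benzyl for 1-(pyridin-2-yl)ethyl gives a 290-fold lower number from compound 2 to compound 4 (2.47 log units; beyond the scatter). A ring nitrogen in this group does not by itself go with a low number, as compound 3, which also holds one, gives 4140 nM. The data shown offer no cause for the step.

The exchange brings in the ring nitrogen and the branching methyl together, so the shown compounds do not tell which of the two carries the step. Pyridin-2-ylmethyl and 1-phenylethyl on the same nitrogen would separate them, and the separate enantiomers of 1-(pyridin-2-yl)ethyl also remain open.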